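Swapping a halogen for trifluoromethyl on the arylpiperazine arm

The source may hold more compounds than are shown below. What is called first, only, known or untested is meant among the compounds shown, and "the series" means these compounds.

Two measured compounds share one core and differ only in the group carried on the phenyl ring attached to the piperazine. Compound 1 `O=C1NC(c2ccccc2)(c2ccccc2)C(=O)N1CN1CCN(c2cccc(Cl)c2)CC1` and compound 2 `O=C1NC(c2ccccc2)(c2ccccc2)C(=O)N1CN1CCN(c2ccc(F)cc2)CC1` were both tested in a functional assay on the whole organism (strain CD1) with Mus musculus as the target, in the maximal electroshock model, with a stated time of 4 h; on this read-out higher numbers stand for an effect only at larger amounts of compound and lower numbers for an effect already at smaller amounts. In this assay compound 1 gives 100 mg/kg, and compound 2 gives 100 mg/kg, so compound 1 stands level with compound 2. Going by the values given here, the one measured step, no change at the digits printed from compound 1 to compound 2 (within the scatter), shows that exchanging one substituted phenyl for another on that nitrogen left the read-out unmoved.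

Compound 3 `O=C1NC(c2ccccc2)(c2ccccc2)C(=O)N1CN1CCN(c2cccc(C(F)(F)F)c2)CC1` has not yet been measured. It differs from compound 1 in one place: trifluoromethyl in place of chloro on an aromatic carbon. Among the compounds with values here, the only measured step concerns a different exchange on the same ring, so it bears on this one loosely, but it points toward no shift beyond the scatter. The step from compound 1 to compound 3 is therefore expected to be no change at the digits printed from compound 1 to compound 3 (within the scatter). Compound 3 is estimated to give 100 mg/kg, within a range from 50 mg/kg to 200 mg/kg.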

Compound 3, minimum effective dose: 100 mg/kg
Compound 3: middle estimate and measured number agree at the digits printed, and the stated range covers the measured number.
By their numbers in this assay, from the lowest: compounds 1, 2 and 3 (each within the scatter of the next).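

In this assay a group of four heavy atoms, trifluoromethyl, takes the place of the single chlorine atom on the same aromatic carbon, meta to a large group, and the outcome is (no change at the digits printed from compound 1 to compound 3 (within the scatter)). Compared with the 4-fluorophenyl group, the 3-(trifluoromethyl)phenyl group gives the same picture (no change at the digits printed from compound 2 to compound 3 (within the scatter)), so all three aryl groups on this nitrogen now lie within the scatter of one another. No available measurement explains this flat result.

The compounds shown leave open whether an amine, a carboxylic acid or a methoxy group on this phenyl ring would move the read-out beyond the scatter. They also leave open whether a longer chain between the shared core and the ring bearing the aryl group would do so.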